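Inverting a cyclopropane stereocentre on a bicyclic amide

The source may report more compounds than this note shows. Statements on the series, on what has been measured and on what is new or still open speak of the compounds shown alone.

Measured compounds:
compound 1 `O=C([C@H]1C[C@H]1F)N1CC2CC(C1)N2` gives 1500 nM in an assay on SH-EP1 cells for agonist activity at Neuronal acetylcholine receptor; alpha4/beta2 (Homo sapiens), read by FLIPR and calcium flux; on this read-out lower numbers stand for an effect already at smaller amounts and higher numbers for an effect only at larger amounts of compound;
compound 2 `O=C([C@@H]1C[C@H]1F)N1CC2CC(C1)N2` gives 870 nM;
compound 3 `C[C@@H]1C[C@@H]1C(=O)N1CC2CC(C1)N2` gives 3800 nM.

Compound 3 carries the highest number of the three, with a 2.5-fold higher number from compound 1 to compound 3 (0.40 log units; beyond the scatter) and a 4.4-fold higher number from compound 2 to compound 3 (0.64 log units; beyond the scatter). Compound 4 `C[C@@H]1C[C@H]1C(=O)N1CC2CC(C1)N2` is its mirror at one place: the two compounds have the same atoms and bonds; at least one stereo element is drawn with a configuration in one of them and without one in the other: 1 of 4 stereo elements differ; a stereocentre at a saturated ring carbon is drawn S in compound 3 and R in compound 4. Among the measured compounds shown here, the one measured step of the same kind is the inversion on the fluorinated three-membered ring, a 1.7-fold lower number from compound 1 to compound 2 (0.24 log units; within the scatter), where the two compounds differ only in the drawn configuration (the fact that one of compounds 1 and 2 is drawn with a defined configuration and the other without, at the place where they differ). That step stayed within the scatter, so for compound 4 no change beyond the scatter is expected in this assay, estimated as a 1.4-fold lower number from compound 3 to compound 4 (0.13 log units; within the scatter). Compound 4 is therefore expected to give about 2800 nM, within a range from 1100 nM to 7000 nM.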

Compound 4, half-maximal effective concentration: 2900 nM
Estimate against measurement, compound 4: 1.0-fold (0.02 log units) below; measured number inside the range.
By their numbers in this assay, from the lowest: compounds 2, 1, 4 and 3 (each within the scatter of the next, the first and the last beyond it).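

The second inversion (a 1.3-fold lower number from compound 3 to compound 4 (0.12 log units; within the scatter)) also stays within the scatter, as the one on the fluorinated ring did, so neither drawn configuration at this ring carbon can be ranked above the other. Methyl in place of fluoro now reads alike on two pairs, with a further step (a 3.3-fold higher number from compound 2 to compound 4 (0.52 log units; beyond the scatter)) beyond the scatter: the same change on two cores in this assay, a 2.5-fold higher number (0.40 log units; beyond the scatter) from compound 1 to compound 3 and a 3.3-fold higher number (0.52 log units; beyond the scatter) from compound 2 to compound 4, 1.3-fold (0.12 log units) apart, within the scatter of two such steps. The pair that goes against this (a 1.9-fold higher number from compound 1 to compound 4 (0.29 log units; within the scatter)) stays within the scatter, but it differs in drawn configuration as well.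

On these data alone, what an amine or a trifluoromethyl at this ring carbon would give in this assay stays open.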